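The source may report more compounds than this note shows. Statements on the series, on what has been measured and on what is new or still open speak of the compounds shown alone.

Measured so far:
Compound 1, `O=c1c(-c2ccc(O)cc2)coc2cc(OCCCCCCCCCCCCO)ccc12` — 1700 nM
Compound 2, `O=C(O)CCCCCOc1ccc2c(=O)cc(-c3ccc(O)cc3)oc2c1` — 3500 nM

Both compounds were tested in an assay (Cricetulus griseus) for inhibition of aldehyde dehydrogenase, mitochondrial (Homo sapiens); on this read-out lower numbers stand for stronger inhibition and higher numbers for weaker inhibition. Compound 1 stands lowest of the two numbers; compound 2 gives the higher number, and the gap between them lies beyond the usual scatter. Compound 3, `C=CCCCCOc1ccc2c(=O)c(-c3ccc(O)cc3)coc2c1`, has not yet been measured. It differs from compound 1 in one place: vinyl in place of 8-hydroxyoctyl on a saturated chain carbon, four bonds along the chain from an oxygen on an aromatic ring. Among the measured compounds shown here, no pair of measured compounds differing in a single place is available, so there is nothing to calibrate this change against; compound 2 differs from compound 1 in more than one way and only shows that a shorter chain with a different end gave a higher number. The step from compound 1 to compound 3 is expected to be modest and toward a higher number in this assay, estimated as a 1.8-fold higher number from compound 1 to compound 3 (0.25 log units; within the scatter). Compound 3 is accordingly expected to give about 3000 nM, with a range from 1200 nM to 8000 nM.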

Compound 3, half-maximal inhibitory concentration: 150 nM
Beside the measured number, compound 3's estimate is 20-fold (1.30 log units) above it; the whole stated range lies above it.
By their numbers in this assay, from the lowest: compound 3; then compound 1; then compound 2.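

Among the compounds shown here, this is the first change in a single place that can be read for this chain. In this assay, putting vinyl in place of 8-hydroxyoctyl on a saturated chain carbon, four bonds along the chain from an oxygen on an aromatic ring, gives an 11-fold lower number from compound 1 to compound 3 (1.05 log units; beyond the scatter). The outer part of the chain therefore matters strongly to this read-out: the long chain with its terminal hydroxyl is not needed for inhibition here, and the much shorter group ending in a double bond goes with the lower number.

Length, the terminal hydroxyl and the double bond all change together in this one step, so the compounds shown cannot separate them; a fully saturated chain of the same length, a long chain ending in vinyl or a chain ending in an amine would be needed to do so. No measurement given here bears on what lies behind the step.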